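This account rests on a few compounds, and the source may have more. Where it says the series, first, only, none or still open, it means among the compounds named here.

Measured so far:
- compound 1 (`COc1ccc(/C=C2\CCC/C(=C\c3cccc(Cl)c3)C2=O)cc1OC`) gives 4900 nM 
- compound 2 (`COc1ccc(/C=C2\CCC/C(=C\c3ccccc3Br)C2=O)cc1OC`) gives 8400 nM 

Within the data shown here, in a functional assay on HT-1080 cells (Homo sapiens) for cytotoxicity, read by MTT assay, with a stated time of 72 h (on this read-out lower numbers stand for stronger inhibition and higher numbers for weaker inhibition), compound 2 gives 8400 nM and compound 1 gives 4900 nM as the only other number. The two lie within the scatter of each other, so compound 2 cannot be ranked against compound 1.

Next is compound 3 (`COc1ccccc1/C=C1\CCC/C(=C\c2ccc(OC)c(OC)c2)C1=O`), which differs from compound 2 in one group, 2-bromophenyl to 2-methoxyphenyl. The change is methoxy in place of bromo on an aromatic carbon on an aromatic carbon, ortho to a large group.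

Among the measured compounds shown here, one measured step bears on this: a 1.7-fold higher number from compound 1 to compound 2 (0.23 log units; within the scatter), with 2-bromophenyl in place of 3-chlorophenyl. For the measured compounds named here, it is a single exchange on the same kind of group, and no measured compound carries 2-methoxyphenyl, so the evidence is thin. On that basis no step beyond the scatter is expected in this assay, and neither direction is favoured.

The estimated step is a 1.2-fold lower number from compound 2 to compound 3 (0.08 log units; within the scatter), which is expected to stay small. For compound 3 the expected value is 7000 nM, with an estimated range from 2500 nM to 18000 nM.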

Compound 3, half-maximal inhibitory concentration: 8100 nM
Beside the measured number, compound 3's estimate is 1.2-fold (0.06 log units) below it, within the range that was stated.
By their numbers in this assay, from the lowest: compounds 1, 3 and 2 (each within the scatter of the next).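

In this assay the exchange of bromo for methoxy on an aromatic carbon, ortho to a large group, gives a 1.0-fold lower number from compound 2 to compound 3 (0.02 log units; within the scatter) and so does not separate the two groups at this place, even though methoxy carries 2 heavy atoms and 1 hydrogen-bond acceptor where bromo carries 1 heavy atom and 0 hydrogen-bond acceptors. The wider exchange of 3-chlorophenyl for 2-methoxyphenyl gives a 1.7-fold higher number from compound 1 to compound 3 (0.22 log units; within the scatter) and separates nothing either, so the earlier single step now has two more beside it and the three groups on this chain carbon still show no ranking in this read-out. Nothing available speaks to what lies behind these numbers.

All three numbers sit within the scatter of their neighbours, so the compounds shown leave open whether any group at this place can move the number beyond the scatter. From the compounds shown here alone, an amine or a carboxylic acid on this aromatic carbon, or a longer chain in place of methoxy, would test that, and whether methoxy gives the same result elsewhere on this ring also remains open.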